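Meta fluoro to methyl on the pendant aryl ring

This account rests on a few compounds, and the source may have more. Where it says the series, first, only, none or still open, it means among the compounds named here.

Two compounds of the shared core have numbers in an assay on isolated protein for binding affinity to adenosine receptor A1 (Rattus norvegicus) (on this read-out higher numbers stand for weaker inhibition and lower numbers for stronger inhibition), so far. Compound 1 `Cn1c(=O)c2nc(-c3cccc(F)c3)[nH]c2n(C)c1=O` gives 2.4 nM in this assay, the higher of the two numbers; compound 2 `Cn1c(=O)c2nc(-c3ccc(Cl)cc3)[nH]c2n(C)c1=O` gives 0.646 nM in this assay, a lower number that lies beyond the scatter from compound 1. Within the data shown here, no pair of measured compounds differs in a single place, so no step within the measured set can be drawn on.

Compound 3 `Cc1cccc(-c2nc3c(=O)n(C)c(=O)n(C)c3[nH]2)c1` differs from compound 1 by methyl in place of fluoro on an aromatic carbon, meta to a large group. Among the measured compounds shown here, with no measured step to compare, the expectation for this change in this assay is a step of no clear direction, not beyond the scatter. Compound 3 is therefore expected to give 2.5 nM in this assay, within 0.7 nM to 9 nM. The expected step is a 1.0-fold higher number from compound 1 to compound 3 (0.02 log units; within the scatter).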

Compound 3, inhibition constant: 5.37 nM
Estimate against measurement, compound 3: 2.1-fold (0.33 log units) below, within the range that was stated.
By their numbers in this assay, from the lowest: compound 2; then compound 1; then compound 3.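

In this assay, among these compounds, this place, meta to a large group, is not indifferent to the substituent: methyl in place of fluoro gives a 2.2-fold higher number from compound 1 to compound 3 (0.35 log units; beyond the scatter) as the first single-place step, modest but beyond the scatter. Of the two groups, each of a single heavy atom, fluoro carries the lower number here, so the exchange is not neutral at this position. No measurement on hand bears on what lies behind this step.

Going by these compounds, with only fluoro and methyl compared at this place, it remains open whether chloro, methoxy or an amine there would give a number lower than that of compound 1. Among the compounds shown here, no single-place step yet links compound 2 to compound 1 or compound 3, so chloro at its position on the ring cannot be weighed against this change.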